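This account rests on a few compounds, and the source may have more. Where it says the series, first, only, none or still open, it means among the compounds named here.

Among the compounds with values here, compound 1 `N#Cc1ccn2c(-c3ccccc3)c(-c3ccccc3)c(CO)c2c1` is the only compound with a result so far: in an assay for inhibition of Polyunsaturated fatty acid lipoxygenase ALOX15 (Oryctolagus cuniculus) (on this read-out lower numbers stand for stronger inhibition and higher numbers for weaker inhibition), compound 1 gives 34000 nM. Compound 2 `COc1ccc(COc2c(-c3ccccc3)c(-c3ccccc3)n3ccc(C#N)cc23)cc1` has no result in this assay, where compound 2 is reported as "not determined" (no result reported), so it stands at no single number. Compound 3 `N#Cc1ccn2c(-c3ccccc3)c(-c3ccccc3)c(C(O)c3ccccc3)c2c1` differs from compound 2 by hydroxy(phenyl)methyl in place of (4-methoxybenzyl)oxy on an aromatic carbon. Within the data shown here, no measured pair shows how such a change shifts inhibition, so neither the size nor the direction of the step in this assay can be read from the data; the one known value is weak. Compound 3 is therefore expected to land near 30000 nM, with a range from 8000 nM to 100000 nM.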

Compound 3, half-maximal inhibitory concentration: 48000 nM
Compound 3: middle estimate off by 1.6-fold (0.20 log units), on the low side, within the range that was stated.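

In this assay the swap of hydrogen for phenyl on the saturated chain carbon gives a 1.4-fold higher number from compound 1 to compound 3 (0.15 log units; within the scatter) and leaves compound 1 and compound 3 indistinguishable. This position therefore carries the extra phenyl ring with no measurable gain in inhibition, and both compounds remain weak. Nothing available explains this result. Compound 2 has no result, so its step to compound 3 cannot be read. From the compounds shown here alone, whether an amine or a carboxylic acid on that chain carbon would shift inhibition remains open.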